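Swapping a piperazine for benzylamine on a shared core

The compounds below may be only part of what the source reports. "The series", "measured", "known", "first", "only" and "open" are said of these compounds alone.

Measured so far:
Compound 1 `CN1CCN(c2nc(Cl)nc3c2ncn3Cc2ccc(C(=O)Nc3ccccc3N)cc2)CC1` gives 71.6%.
Compound 2 `CC(C)n1cnc2c(Nc3ccccc3)nc(NCOCc3ccc(C(=O)Nc4ccccc4N)cc3)nc21` gives 6.85%.
Compound 3 `CCC(C)n1cnc2c(NCc3ccc(C(=O)Nc4ccccc4N)cc3)nc(Cl)nc21` gives 74.6%.

All three were tested in a functional assay on HCT-116 cells (Homo sapiens) for antiproliferative activity, read by CCK-8 assay, with a stated time of 72 h, tested at 2 uM; on this read-out higher numbers stand for a stronger effect at the one concentration tested and lower numbers for a weaker effect. Among the three numbers, compound 1 stands second highest; its value and that of compound 3 lie within the scatter of each other, so neither can be called stronger. Compound 2 lies far lower, beyond the scatter.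

Compound 4 `Nc1ccccc1NC(=O)c1ccc(Cn2cnc3c(NCc4ccccc4)nc(Cl)nc32)cc1` has not yet been measured. Its structure is derived from compound 1 by one change, (benzylamino in place of 4-methylpiperazin-1-yl on an aromatic carbon). Going by the values given here, no pair of measured compounds differs in exactly one place, so no measured step describes this swap directly. Compound 3, which also carries an amino link to an aromatic ring on its core, gives 74.6%, and that offers some guidance.

On this basis, the step from compound 1 to compound 4 is expected to be small, not beyond the scatter: a number 1.6 percentage points lower from compound 1 to compound 4 (within the scatter). Compound 4 is estimated at 70%, within a range from 50% to 85%.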

Compound 4, a percentage reported as inhibition, at one concentration (the size of the read-out at that concentration, not a potency): 68.3%
For compound 4 the middle estimate is 1.7 percentage points above the measured one; the measured number falls inside the stated range.
By their numbers in this assay, from the lowest: compound 2; then compounds 4, 1 and 3 (each within the scatter of the next).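

In this assay, benzylamino in place of 4-methylpiperazin-1-yl on the aromatic carbon next to the ring nitrogen of the shared core gives a number 3.3 percentage points lower from compound 1 to compound 4 (within the scatter). This one-place comparison shows that two quite different groups, a non-aromatic ring with two hetero atoms and an amino link carrying an all-carbon aromatic ring, give readings that cannot be told apart at this position at the one concentration tested. No measurement here accounts for this result.

On these data alone, whether the position stays this open to change remains unknown for a plain amine, a morpholine ring or a benzylamino group bearing a carboxylic acid on its ring. A single concentration also leaves open whether compound 1 and compound 4 would separate in potency across a range of concentrations.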